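The source may report more compounds than this note shows. Statements on the series, on what has been measured and on what is new or still open speak of the compounds shown alone.

In a functional assay on A549 cells (Homo sapiens) for cytotoxicity, read by resazurin assay, with a stated time of 48 h (a higher number here means a weaker inhibitor, a lower number a stronger inhibitor), three compounds sharing one core have been measured. Compound 1 `C=C(C)[C@@H]1CC=C(CN(OC)C2O[C@H](CO)[C@@H](N=[N+]=[N-])[C@H](O)[C@H]2O)CC1` gives 4000 nM, compound 2 `C=C(C)[C@@H]1CC=C(CN(OC)C2O[C@H](CO)[C@@H](O)[C@H](NC(=O)CCCCCCCCC)[C@H]2O)CC1` gives 14000 nM, and compound 3 `C=C(C)[C@@H]1CC=C(CN(OC)C2O[C@H](CN=[N+]=[N-])[C@@H](N=[N+]=[N-])[C@H](O)[C@H]2O)CC1` gives 44000 nM, the highest of the three numbers. Compound 4 `C=C(C)[C@@H]1CC=C(CN(OC)C2O[C@H](CN=[N+]=[N-])[C@@H](O)[C@H](O)[C@H]2O)CC1` has not yet been measured. It differs from compound 3 by a single change, hydroxy in place of azido on a saturated ring carbon, while the azidomethyl group stays. For the measured compounds named here, no measured step makes this same change. The closest evidence is an 11-fold higher number from compound 1 to compound 3 (1.04 log units; beyond the scatter), a large rise on introducing the azidomethyl group, but that step acts at a different place and bears on the new change only loosely. Like compound 1, compound 4 would carry a single azido, though elsewhere, so a lower number is expected, smaller in size than that rise and not far beyond the scatter. The expected change is a 2.4-fold lower number from compound 3 to compound 4 (0.39 log units; beyond the scatter). For compound 4 the estimated value is 18000 nM, within an expected range from 5000 nM to 60000 nM.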

Compound 4, half-maximal inhibitory concentration: 163000 nM
For compound 4 the middle estimate is 9.1-fold (0.96 log units) below the measured one; measured number above the stated range.
By their numbers in this assay, from the lowest: compound 1; then compound 2; then compound 3; then compound 4.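

For the compounds shown here, on this saturated ring carbon, next to the ring atom that bears an azidomethyl group, the azido group is not the burden that the earlier compounds might have suggested: in this assay, taking it out for hydroxy gives a 3.7-fold higher number from compound 3 to compound 4 (0.57 log units; beyond the scatter), a modest step beyond the scatter. Set beside an 11-fold higher number from compound 1 to compound 3 (1.04 log units; beyond the scatter), which adds azido on the chain carbon, this shows that the two azido positions do not act alike, since azido in place of hydroxy goes with a higher number on the chain and a lower number on this ring carbon. Nothing measured here explains this difference in direction.

The compounds shown leave open whether an amine or a methoxy group on this ring carbon would track with azido or with hydroxy. They also leave open whether the same exchange would run in the same direction with a plain hydroxymethyl group in place of the azidomethyl group.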